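Swapping the aryl substituent on the amide of compound 3

The compounds below may be only part of what the source reports. "The series", "measured", "known", "first", "only" and "open" are said of these compounds alone.

Measured compounds:
- compound 1, `COC(=O)c1cccc(C(=O)N2CCC(N(C3CC3)S(=O)(=O)c3cccc(C(F)(F)F)c3)CC2)c1`, "not determined" (no result reported) in an assay on cells for inhibition of Voltage-dependent L-type calcium channel subunit alpha-1C (Homo sapiens), read by FLIPR and calcium flux, tested at 3 uM; a lower number here means a weaker effect, a higher number a stronger effect of the compound at the concentration tested
- compound 2, `NC(=O)c1ccccc1C(=O)N1CCC(N(C2CC2)S(=O)(=O)c2cccc(C(F)(F)F)c2)CC1`, 17%
- compound 3, `CS(=O)(=O)c1ccccc1C(=O)N1CCC(N(C2CC2)S(=O)(=O)c2cccc(C(F)(F)F)c2)CC1`, 39%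

All three share one core, a piperidine bearing a cyclopropyl-substituted sulfonamide and an aryl amide. Compound 1 has no number in this assay. Among the two compounds with numbers, compound 3 stands highest; its nearest neighbour is compound 2, and the only measured step, a number 22 percentage points higher from compound 2 to compound 3 (beyond the scatter), is modest but beyond the scatter.

Compound 4 is `CN(C)c1cccc(C(=O)N2CCC(N(C3CC3)S(=O)(=O)c3cccc(C(F)(F)F)c3)CC2)c1`. Relative to compound 3, the change is 3-(dimethylamino)phenyl in place of 2-(methylsulfonyl)phenyl on a carbonyl carbon. For the measured compounds named here, the one measured step replaced one group on this same aromatic ring with another, so it bears on the new change only loosely: it shows that this ring's substituent can shift the read-out by a modest amount, but the new group differs from both groups seen so far, and no measured pair shows the effect of removing the sulfonyl or adding the dimethylamino group. The expectation is therefore uncertain; a modest downward step, a number 14 percentage points lower from compound 3 to compound 4 (beyond the scatter), is expected rather than a gain, since compound 3 already holds the higher value and the entering group resembles neither of the two that were measured. For compound 4 the estimated inhibition is 25%, with a range from 5% to 45%.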

Compound 4, a percentage reported as inhibition, at one concentration (the size of the read-out at that concentration, not a potency): 63%
For compound 4 the middle estimate is 38 percentage points below the measured one, outside the stated range (above it).
By their numbers in this assay, from the lowest: compound 2; then compound 3; then compound 4.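

In this assay, the aryl group on the carbonyl carbon turns out to have more room for gain than the two earlier groups suggested, with a number 24 percentage points higher from compound 3 to compound 4 (beyond the scatter) and a number 46 percentage points higher from compound 2 to compound 4 (beyond the scatter). Compound 4 therefore stands highest of the three compounds with numbers, and its 3-(dimethylamino)phenyl group shows that neither the methylsulfonyl nor the carbamoyl group is needed for a stronger effect at the concentration tested. Nothing available here explains why this group gives the higher number.

The step from compound 3 to compound 4 changes both the substituent and the number in the group's name, so the compounds shown cannot separate the contribution of the dimethylamino group from that of where it sits on the ring. Going by these compounds, it also remains open how an unsubstituted phenyl ring, a 2-(dimethylamino)phenyl group or a ring carrying a primary amine or a carboxylic acid would compare, and so whether the nitrogen of the dimethylamino group matters at all.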